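The source may hold more compounds than are shown below. What is called first, only, known or untested is meant among the compounds shown, and "the series" means these compounds.

Three sulfonamides sharing one core have been tested in a functional assay on MIA PaCa-2 cells (Homo sapiens) for inhibition, read by MTT assay, with a stated time of 72 h; on this read-out lower numbers stand for stronger inhibition of growth and higher numbers for weaker inhibition of growth. Compound 1 `O=S(=O)(NCCCCCCNCc1ccc(Br)cc1)c1ccc(C(F)(F)F)cc1` gives 3830 nM. Compound 2 `CCCCc1ccc(S(=O)(=O)NCCCCCCNCc2ccc(Br)cc2)cc1` gives 5700 nM. Compound 3 `CC(C)c1ccc(S(=O)(=O)NCCCCCCNCc2ccc(Br)cc2)cc1` gives 5730 nM. Among these three numbers compound 3 holds the highest, but its steps to the other two are within the scatter: the change a 1.5-fold higher number from compound 1 to compound 3 (0.17 log units; within the scatter) and the change a 1.0-fold higher number from compound 2 to compound 3 (0.00 log units; within the scatter) are both too small to count as real differences, as is a 1.5-fold higher number from compound 1 to compound 2 (0.17 log units; within the scatter).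

The next compound, compound 4 `CC(C)(C)c1ccc(S(=O)(=O)NCCCCCCNCc2ccc(Br)cc2)cc1`, differs from compound 3 by methyl in place of hydrogen on a saturated chain carbon bound to an aromatic carbon and two saturated chain carbons. For the measured compounds named here, the steps that bear on this are the three measured ones, all of which swap one alkyl or trifluoromethyl group for another on the same aromatic carbon, and none of them moved the number beyond the scatter. On that basis the change from compound 3 to compound 4 is expected to give no step beyond the scatter in this assay, with a 1.0-fold lower number from compound 3 to compound 4 (0.00 log units; within the scatter) as the expected size. Compound 4 is therefore estimated at 5700 nM, with a range from 2500 nM to 13000 nM.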

Compound 4, concentration for 50% growth inhibition: 2970 nM
Estimate against measurement, compound 4: 1.9-fold (0.28 log units) above; the measured number falls inside the stated range.
By their numbers in this assay, from the lowest: compounds 4, 1, 2 and 3 (each within the scatter of the next).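

In this assay the change from isopropyl to tert-butyl, methyl in place of hydrogen on a saturated chain carbon bound to an aromatic carbon and two saturated chain carbons, amounts to a 1.9-fold lower number from compound 3 to compound 4 (0.29 log units; within the scatter) and so shows that this carbon takes the added methyl with no step beyond the scatter. Tert-butyl also stands level with the other groups on the same aromatic carbon, with a 1.9-fold lower number from compound 2 to compound 4 (0.28 log units; within the scatter) against butyl and a 1.3-fold lower number from compound 1 to compound 4 (0.11 log units; within the scatter) against trifluoromethyl, which extends the flat picture of the earlier compounds to a fourth group. No information is at hand on why these four groups cannot be told apart on this read-out.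

Going by these compounds, all four groups are joined to the aromatic carbon through carbon, so it stays open whether a carboxylic acid, an amine or a hydroxyl group in their place would give a step beyond the scatter. On these data alone, how a longer chain in place of the chain shared by all four compounds, or chlorine in place of their bromine, would shift the number is equally open.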